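The source may report more compounds than this note shows. Statements on the series, on what has been measured and on what is new or still open speak of the compounds shown alone.

In a functional assay on SiHa cells (Homo sapiens) for antiproliferative activity, read by CCK-8 assay, with a stated time of 72 h (a higher number here means a weaker inhibitor, a lower number a stronger inhibitor), compound 1 `COc1ccc(-c2cncnc2-c2cc(OC)c(OC)c(OC)c2)cc1` gives 2850 nM and compound 2 `COc1ccc(-c2cncnc2-c2cc(OC)c(OC)c(OC)c2)cc1O` gives 2750 nM with a hydroxy added, a step that stays within the scatter (a 1.0-fold lower number from compound 1 to compound 2 (0.02 log units; within the scatter)). Compound 3 `CCSc1ccc(-c2cncnc2-c2cc(OC)c(OC)c(OC)c2)cc1` gives 1030 nM and holds the lowest number of the three. Two modest steps beyond the scatter lead to it (a 2.8-fold lower number from compound 1 to compound 3 (0.44 log units; beyond the scatter), and a 2.7-fold lower number from compound 2 to compound 3 (0.43 log units; beyond the scatter)).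

Compound 4 `COc1cc(-c2ncncc2-c2ccc(OCC(F)(F)F)cc2)cc(OC)c1OC` carries 2,2,2-trifluoroethoxy in place of ethylsulfanyl on an aromatic carbon of a six-membered aromatic ring of carbon only, para to a large group (2,2,2-trifluoroethoxy in place of ethylsulfanyl on an aromatic carbon). For the measured compounds named here, no measured compound carries this group, so the evidence is indirect. Going by the values given here, the nearest guide is the only other swap measured at this place, ethylsulfanyl in place of methoxy (a 2.8-fold lower number from compound 1 to compound 3 (0.44 log units; beyond the scatter)). Its modest size argues against a large move here. A small step in this assay is expected, toward a higher number. The estimated step is a 1.6-fold higher number from compound 3 to compound 4 (0.19 log units; within the scatter) and it may well lie within the scatter. For compound 4 the estimate is 1600 nM as the middle value, with the expected range running from 600 nM to 4000 nM in this series.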

Compound 4, half-maximal inhibitory concentration: 33300 nM
Compound 4: middle estimate off by 21-fold (1.32 log units), on the low side, outside the stated range (above it).
By their numbers in this assay, from the lowest: compound 3; then compounds 2 and 1 (each within the scatter of the next); then compound 4.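

In this assay this aromatic carbon, para to a large group, proves far less forgiving than the earlier swaps suggested: 2,2,2-trifluoroethoxy in place of ethylsulfanyl costs a large step (a 32-fold higher number from compound 3 to compound 4 (1.51 log units; beyond the scatter)), whereas the earlier changes there moved the number modestly or not beyond the scatter. The oxygen-linked pair adds a sharper point: trifluoromethyl in place of hydrogen on the saturated chain carbon bound to the oxygen also gives a large step (a 12-fold higher number from compound 1 to compound 4 (1.07 log units; beyond the scatter)), so an oxygen at this place does not by itself protect the activity, and the change at the chain end is enough to produce the loss. Nothing measured here accounts for this loss, and the series offers no cause for it.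

The compounds shown leave open whether the loss follows the fluorine atoms or the longer chain, a question that a plain ethoxy group on the same aromatic carbon would separate. A 2,2,2-trifluoroethylsulfanyl group would test whether the sulfur link changes the outcome, and an amine or a carboxylic acid at the chain end would show how far the position tolerates other kinds of group.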